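From 4-methylbenzyl to 4-chlorobenzyl on a shared core

The source may report more compounds than this note shows. Statements on the series, on what has been measured and on what is new or still open speak of the compounds shown alone.

In a functional assay on NB1 cells (Homo sapiens) for antiproliferative activity, with a stated time of 72 h (a higher number here means a weaker inhibitor, a lower number a stronger inhibitor), compound 1 (`Cc1ccc(CNC(=O)CCN(Cc2ccc(C(=O)NO)cc2)C(=O)c2ccc(N(C)C)cc2)cc1`) gives 700 nM. Compound 2 (`COc1cc(OC)cc(C(=O)N(CCC(=O)NCc2ccccc2)Cc2ccc(C(=O)NO)cc2)c1`) gives 13300 nM in this assay, which leaves compound 1 with the lower of the two numbers, by a gap beyond the scatter. These two compounds differ in more than one place, so their gap does not speak to any single change.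

Compound 3 (`CN(C)c1ccc(C(=O)N(CCC(=O)NCc2ccc(Cl)cc2)Cc2ccc(C(=O)NO)cc2)cc1`) has not yet been measured. It departs from compound 1 in one place: chloro in place of methyl on an aromatic carbon. This puts chloro in place of methyl on an aromatic carbon, para to a large group, turning 4-methylbenzyl into 4-chlorobenzyl. Going by the values given here, no measured pair here shows this change, so no shift beyond the scatter is expected in this assay. The expected step is small: a 1.2-fold lower number from compound 1 to compound 3 (0.07 log units; within the scatter). Compound 3 is estimated at 600 nM, with an expected range of 250 nM to 1500 nM.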

Compound 3, half-maximal inhibitory concentration: 850 nM
The estimate for compound 3 lay 1.4-fold (0.15 log units) below the measured number; the measured number falls inside the stated range.
By their numbers in this assay, from the lowest: compounds 1 and 3 (each within the scatter of the next); then compound 2.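

Going by these compounds alone, the change from 4-methylbenzyl to 4-chlorobenzyl provides the only one-place comparison here in this assay, and it reads a 1.2-fold higher number from compound 1 to compound 3 (0.08 log units; within the scatter). At this aromatic carbon, para to a large group, chloro in place of methyl therefore leaves the antiproliferative read-out indistinguishable from that of the parent, and compound 1 and compound 3 cannot be ranked against each other. Nothing available here speaks to a cause for this result.

As far as these compounds go, it remains open whether a very different group at this carbon, such as an amine, a carboxylic acid or trifluoromethyl, would also leave the number unchanged. Compound 2 differs from compound 1 in more than one place, so its gap to compound 1 still cannot be assigned to any single change.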